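A few compounds are considered here, and "the series" means these few. Any claim that something is new, unique, unknown or untested is made for them only; others in the source may bear on it.

Measured so far in an ADME assay on cells (Hepatocyte, Rattus norvegicus) for metabolic stability, with a stated time of 90 min; on this read-out higher numbers stand for fast clearance and lower numbers for slow clearance: compound 1 `C[C@@H](Nc1c(C(N)=O)cnc2ccc(-c3cccnc3)cc12)c1ccc(Cl)cc1` gives 70 uL/min; compound 2 `NC(=O)c1cnc2ccc(-c3cccnc3)cc2c1NC1CCCC1` gives 65 uL/min; compound 3 `NC(=O)c1cnc2ccc(-c3cccnc3)cc2c1SC1CCCC1` gives 120 uL/min.

Compound 3 stands at the top of these three numbers, but the scatter does not secure that standing, since compound 1 and compound 2 both lie within it. Compound 4 `NC(=O)c1cnc2ccc(-c3cccnc3)cc2c1NC1CCCCC1` differs from compound 3 by cyclohexylamino in place of cyclopentylsulfanyl on an aromatic carbon. Going by the values given here, two measured steps bear on this. The step of a 1.1-fold lower number from compound 1 to compound 2 (0.03 log units; within the scatter) shows the nitrogen substituent swapped with little effect. The step of a 1.8-fold higher number from compound 2 to compound 3 (0.27 log units; within the scatter) is the reverse of the sulfur-to-nitrogen part of the present change, and it too stayed within the scatter. Compound 2 is the closest measured analogue, so compound 4 is expected to fall near it, at 75 uL/min (range 40 uL/min to 150 uL/min), an estimated 1.6-fold lower number from compound 3 to compound 4 (0.20 log units; within the scatter).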

Compound 4, intrinsic clearance in a liver preparation (reported as CLH), per the amount of preparation that the assay uses: 70 uL/min
The estimate for compound 4 lay 1.1-fold (0.03 log units) above the measured number; low and high end bracket the measured number.
By their numbers in this assay, from the lowest: compounds 2, 1, 4 and 3 (each within the scatter of the next).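

In this assay, cyclohexyl in place of cyclopentyl on the nitrogen gives a 1.1-fold higher number from compound 2 to compound 4 (0.03 log units; within the scatter), so this change in ring size leaves no readable mark. Cyclohexyl in place of 1-(4-chlorophenyl)ethyl gives no change at the digits printed from compound 1 to compound 4 (within the scatter), and cyclohexylamino in place of cyclopentylsulfanyl gives a 1.7-fold lower number from compound 3 to compound 4 (0.23 log units; within the scatter). All four groups at this position, ortho to the carbamoyl group, thus stay within the scatter of one another. On these data alone, whether a carboxylic acid, a morpholine ring or a longer alkyl chain here would also stay within it remains open. Nothing shown accounts for how close these numbers lie.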